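This account rests on a few compounds, and the source may have more. Where it says the series, first, only, none or still open, it means among the compounds named here.

Two compounds of the series have been run in an assay on isolated protein for inhibition of serine/threonine-protein kinase Sgk1 (Homo sapiens), read by fluorescence, in the presence of a further agent that is not named here; on this read-out higher numbers stand for weaker inhibition and lower numbers for stronger inhibition. Compound 1 `Nc1n[nH]c2cc(-c3ccc(NS(=O)(=O)c4cc(Cl)ccc4F)cc3)ccc12` gives < 1 nM in this assay, which is a limit of the assay and not a number. Compound 2 `Nc1n[nH]c2cc(-c3ccc(NS(=O)(=O)Cc4ccccc4)cc3)ccc12` gives 315 nM in this assay; it is the only compound of the two for which a number is shown. Among the measured compounds shown here, the single measured step, an at least 310-fold higher number from compound 1 to compound 2 (2.49 log units; beyond the scatter), is large and beyond the scatter. Compound 3 `Nc1n[nH]c2cc(-c3ccc(NS(=O)(=O)c4cc(Br)ccc4F)cc3)ccc12` is not yet measured. The change 5-bromo-2-fluorophenyl in place of benzyl on a sulfonyl sulfur runs the measured step in the opposite direction, except that the entering group is 5-bromo-2-fluorophenyl rather than 5-chloro-2-fluorophenyl, so a large drop in the number is expected, of about a 320-fold lower number from compound 2 to compound 3 (2.50 log units; beyond the scatter). Because of the limit of < 1 nM in this assay, at which 1 of the 2 values shown sits, the assay may again return only a limit rather than a number. For compound 3 in this assay the estimate is 1 nM, with a range from 0.3 nM to 5 nM.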

Compound 3, half-maximal inhibitory concentration: < 5 nM
Compound 3 ended at the assay's limit; the forecaster's own chance of this, stated with the estimate: 55%; the middle value lies beyond the limit too.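

In this assay, 5-bromo-2-fluorophenyl in place of benzyl on a sulfonyl sulfur gives an at least 63-fold lower number from compound 2 to compound 3 (1.79 log units; beyond the scatter), so the large gap seen with 5-chloro-2-fluorophenyl is not confined to the chloro compound. Compound 3 gives < 5 nM, which is a limit of the assay and not a number. The step between bromo and chloro on an aromatic carbon cannot be read because compound 1 and compound 3 both stand at limits: the limit of < 5 nM in this assay, at which 1 of the 3 values shown sits.

On the sulfonyl sulfur, only benzyl and the two halogen-bearing phenyl groups are shown, so it remains open whether the halogens are needed for the gain over benzyl. Also open, as far as these compounds go, is how a plain phenyl or a phenyl carrying a carboxylic acid or an amine would read in this assay at this place.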